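From methoxy to 3-bromophenyl in a liver cell assay

This account rests on a few compounds, and the source may have more. Where it says the series, first, only, none or still open, it means among the compounds named here.

The series rests on one core, carried by compound 1 `C=C[C@@](C)(/C=C/c1ccc(OC)cc1)CCC=C(C)C`. In a functional assay on HepG2 cells (Homo sapiens) for cytotoxicity, with a stated time of 72 h (on this read-out higher numbers stand for an effect only at larger amounts of compound and lower numbers for an effect already at smaller amounts), compound 1 gives only a limit of > 52000 nM, not a number. Compound 2 `C=C[C@@](C)(/C=C/c1ccc(O)c(/C=C/C#N)c1)CCC=C(C)C` likewise reaches only the limit of > 52000 nM in this assay. Compound 3 `COc1ccc(/C=C/[C@@](C)(/C=C/c2ccc(O)c(C=O)c2)CCC=C(C)C)cc1` stops at the limit of > 26000 nM in this assay. So compound 1 stands where most of the set stands: the limit of > 52000 nM in this assay, at which 2 of the 3 values shown sit, while the remaining value sits at the limit of > 26000 nM in this assay, at which 1 of the 3 values shown sits. No measured step between any two of these compounds exists, and no pattern can be drawn from them.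

Compound 4 `C=C[C@@](C)(/C=C/c1ccc(-c2cccc(Br)c2)cc1)CCC=C(C)C` has not yet been measured. It differs from compound 1 in one place: 3-bromophenyl in place of methoxy on an aromatic carbon. Among the compounds with values here, with compound 1 only at a limit, no measured step supports a direction; the step is expected to stay within the scatter or to bring compound 4 somewhat lower, so that compound 4 is estimated at 35000 nM, between 12000 nM and 100000 nM, an expected step of an at least 1.4-fold lower number from compound 1 to compound 4 (0.17 log units; that floor lies within the scatter).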

Compound 4, half-maximal effective concentration: > 52000 nM
Compound 4 ended at the assay's limit; the forecaster's own chance of this, stated with the estimate: 55%; at least 1.4-fold (0.17 log units) between middle value and limit.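

In this assay compound 4 gives only a limit of > 52000 nM, and it joins most of the set: the limit of > 52000 nM in this assay, at which 3 of the 4 values shown sit. Compound 1 also stands at a limit, and the step between compound 1 and compound 4 cannot be read. The compounds shown leave open whether 3-bromophenyl in place of methoxy changes the read-out at all.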